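From Aryl Carbonyl to Aryl Sulfonyl on the Ring Nitrogen

A few compounds are considered here, and "the series" means these few. Any claim that something is new, unique, unknown or untested is made for them only; others in the source may bear on it.

Compound 2 `Cc1ccc(C(=O)N2N=C(c3ccc(N4CCN(C)CC4)cc3)CC2c2ccc(N(C)C)cc2)cc1` has been measured in a functional assay on NCI-H1975 cells (Homo sapiens) for inhibition, read by sulforhodamine B assay, tested at 10 uM (on this read-out higher numbers stand for more inhibition at the one concentration tested (going by the name of the read-out) and lower numbers for less inhibition), where compound 2 gives -0.4%. Among the three numbers it is the second highest: its nearest neighbour is compound 1 `COC(=O)CC(=O)N1N=C(c2ccc(N3CCN(C)CC3)cc2)CC1c1ccc(N(C)C)cc1`, which gives -2.2%, a pair that lies within the scatter, and the furthest is compound 3 `CN1CCN(c2ccc(C3=NN(S(=O)(=O)c4ccc(F)cc4)C(c4ccc(N(C)C)cc4)C3)cc2)CC1`, which gives 95.7%. The step of a number 1.8 percentage points higher from compound 1 to compound 2 (within the scatter) changes nothing beyond the scatter, whereas a number 96.1 percentage points higher from compound 2 to compound 3 (beyond the scatter) and a number 97.9 percentage points higher from compound 1 to compound 3 (beyond the scatter) are both large.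

Compound 4 `CN1CCN(c2ccc(C3=NN(S(=O)(=O)c4ccc(Br)cc4)C(c4ccc(N(C)C)cc4)C3)cc2)CC1` has not yet been measured. Compared with compound 2 the change is (4-bromophenyl)sulfonyl in place of (4-methylphenyl)carbonyl on an amine nitrogen in a ring. The measured step that bears on it is a number 96.1 percentage points higher from compound 2 to compound 3 (beyond the scatter), in which the same kind of replacement on the same ring nitrogen, with a (4-fluorophenyl)sulfonyl group entering, raised the read-out sharply; a number 97.9 percentage points higher from compound 1 to compound 3 (beyond the scatter) points the same way. The two changes differ only in bromine in place of fluorine in the entering group, and with a number 96.1 percentage points higher from compound 2 to compound 3 (beyond the scatter) as the guide a large rise is expected. Compound 4 is therefore expected to give about 90%, within a range of 60% to 100%. This expectation amounts to an estimated step of a number 90.4 percentage points higher from compound 2 to compound 4 (beyond the scatter).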

Compound 4, a percentage reported as inhibition, at one concentration (the size of the read-out at that concentration, not a potency): 70.8%
The estimate for compound 4 lay 19.2 percentage points above the measured number; the range from low to high includes it.
By their numbers in this assay, from the lowest: compounds 1 and 2 (each within the scatter of the next); then compound 4; then compound 3.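

Compound 4 shows that the large rise on the ring nitrogen does not belong to the (4-fluorophenyl)sulfonyl group alone: a second arylsulfonyl group gives a number 71.2 percentage points higher from compound 2 to compound 4 (beyond the scatter) and a number 73 percentage points higher from compound 1 to compound 4 (beyond the scatter) in this assay. It also shows that the atom on the aromatic ring of the entering group counts, since bromo in place of fluoro gives a number 24.9 percentage points lower from compound 3 to compound 4 (beyond the scatter), a modest step beyond the scatter but much smaller than either rise. On these four compounds, then, the sulfonyl compounds stand far above the carbonyl compounds, and no compound goes against that split, while the halogen shifts the read-out within the sulfonyl pair; no measurement at hand offers a reason for either step.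

The compounds shown leave open how much of the rise comes from the sulfonyl link and how much from the halogen, as the two change together in every step from a carbonyl to a sulfonyl compound. A (4-fluorophenyl)carbonyl group would separate the two, and a (4-chlorophenyl)sulfonyl or a methylsulfonyl group on the same nitrogen remains an open case.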